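The source may report more compounds than this note shows. Statements on the series, on what has been measured and on what is new or still open speak of the compounds shown alone.

Compound 3 `Nc1ccccc1NC(=O)c1ccc(CSC(=S)N2CCN(c3cnccn3)CC2)cc1` gives 70.4% in a functional assay on HeLa cells (Homo sapiens) for antiproliferative activity, read by CCK-8 assay, with a stated time of 72 h, tested at 2 uM (on this read-out lower numbers stand for a weaker effect and higher numbers for a stronger effect at the one concentration tested), the highest of the three numbers measured. Compound 2 `Nc1ccccc1NC(=O)c1ccc(CSC(=S)N2CCN(Cc3ccncc3)CC2)cc1` gives 59.5% in this assay, and compound 1 `Nc1ccccc1NC(=O)c1ccc(CSC(=S)N2CCN(C3CCCCC3)CC2)cc1` gives 30.6%. The steps between them all change the group on the ring nitrogen: a number 39.8 percentage points higher from compound 1 to compound 3 (beyond the scatter), a number 28.9 percentage points higher from compound 1 to compound 2 (beyond the scatter) and a number 10.9 percentage points higher from compound 2 to compound 3 (beyond the scatter).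

Compound 4 `N#Cc1ccc(N2CCN(C(=S)SCc3ccc(C(=O)Nc4ccccc4N)cc3)CC2)cc1` differs from compound 3 by 4-cyanophenyl in place of pyrazin-2-yl on an amine nitrogen in a ring. Every measured step bears on it, since each swaps that same group, and each aromatic ring gave more inhibition than cyclohexyl. The entering ring is aromatic but carbon only, so a modest fall in this assay, or none beyond the scatter, is expected for compound 4, as the step of a number 10.4 percentage points lower from compound 3 to compound 4 (beyond the scatter) shows. Compound 4 is therefore estimated at 60%, between 40% and 80%.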

Compound 4, a percentage reported as inhibition, at one concentration (the size of the read-out at that concentration, not a potency): 71.6%
Compound 4: the middle estimate sits 11.6 percentage points below what was measured, and the stated range covers the measured number.
By their numbers in this assay, from the lowest: compound 1; then compound 2; then compounds 3 and 4 (each within the scatter of the next).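

With a number 1.2 percentage points higher from compound 3 to compound 4 (within the scatter) in this assay the swap shows that a ring of carbon only carrying a nitrile can stand in for the pyrazin-2-yl ring, so nitrogen inside the ring is not required at this position. The 4-cyanophenyl group also stays ahead of the two earlier groups, with a number 12.1 percentage points higher from compound 2 to compound 4 (beyond the scatter) and a number 41 percentage points higher from compound 1 to compound 4 (beyond the scatter) as its steps. No measurement shown explains these differences. Going by these compounds, whether the nitrile itself matters remains open, and a plain phenyl ring or a phenyl ring bearing a carboxylic acid would test that. Readings at one concentration also leave the potency of these compounds unknown.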